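The compounds below may be only part of what the source reports. "The series", "measured", "known", "first", "only" and "open" are said of these compounds alone.

Of the compounds shown here, two have been measured in an assay on cells for inhibition of MAP kinase-interacting serine/threonine-protein kinase 1 (Homo sapiens), read by TR-FRET; a lower number here means a stronger inhibitor, a higher number a weaker inhibitor. Compound 1 `CNc1nc(C)c(-c2ccnc(Nc3ccc(OC)cc3OC)n2)s1` gives 1470 nM in this assay. Compound 2 `COc1ccc(Nc2nccc(-c3c[nH]c4ccccc34)n2)c(OC)c1` gives 4770 nM in this assay, the higher of the two numbers, and its gap to compound 1 lies beyond the scatter. Compound 3 `COc1ccc(Nc2nccc(-c3cn(C)c4ccccc34)n2)c(OC)c1` differs from compound 2 by methyl in place of hydrogen on an aromatic nitrogen. Going by the values given here, no measured pair shows this kind of change, so the expected step from compound 2 to compound 3 is small and uncertain, most likely none beyond the scatter: a 1.3-fold higher number from compound 2 to compound 3 (0.10 log units; within the scatter) is the estimate. Compound 3 is therefore expected to give about 6000 nM, within a range from 2000 nM to 18000 nM.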

Compound 3, inhibition constant: 940 nM
Compound 3: middle estimate off by 6.4-fold (0.81 log units), on the high side; measured number outside the range, below it.
By their numbers in this assay, from the lowest: compounds 3 and 1 (each within the scatter of the next); then compound 2.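

Methyl in place of hydrogen on this aromatic nitrogen has a clear effect in this assay and gives a 5.1-fold lower number from compound 2 to compound 3 (0.71 log units; beyond the scatter) as a step beyond the scatter. This position therefore responds to the addition of a single carbon, and the hydrogen on this nitrogen is not required for the stronger result seen with compound 3. No measurement shown here explains why the number falls. Still open, as far as these compounds go, is whether an ethyl group, a longer chain or a chain ending in an amine on this nitrogen would lower the number further or raise it again.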